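Swapping the Aromatic Group: Compound 3 to Compound 4

The source may hold more compounds than are shown below. What is called first, only, known or untested is meant among the compounds shown, and "the series" means these compounds.

Measured so far, in a functional assay on LNCaP cells (Prostate gland, Homo sapiens) for antiproliferative activity, read by sulforhodamine B assay; a lower number here means a stronger inhibitor, a higher number a weaker inhibitor:
- compound 1 `CCCCCCCCCCCCCCCCCCNC(=O)[C@H]1CSC(Cc2ccccc2)N1` gives 4400 nM
- compound 2 `CCCCCCCCCCCCCCCCCCNC(=O)[C@H]1CSC(c2cccnc2)N1` gives 3600 nM
- compound 3 `CCCCCCCCCCCCCCCCCCNC(=O)[C@H]1CSC(c2ccc(N(C)C)cc2)N1` gives 1600 nM

Compound 3 holds the lowest number of the three, and its distance to both neighbours lies beyond the scatter, so it is the strongest inhibitor among them in this assay. Compound 4 `CCCCCCCCCCCCCCCCCCNC(=O)[C@H]1CSC(c2cccc(O)c2)N1` differs from compound 3 in one place: 3-hydroxyphenyl in place of 4-(dimethylamino)phenyl on a saturated ring carbon. Going by the values given here, two measured steps bear on this change, since both end in the group that now leaves: a 2.8-fold lower number from compound 1 to compound 3 (0.44 log units; beyond the scatter) and a 2.3-fold lower number from compound 2 to compound 3 (0.35 log units; beyond the scatter). Both were modest gains when the 4-(dimethylamino)phenyl group entered. By contrast, a 1.2-fold lower number from compound 1 to compound 2 (0.09 log units; within the scatter) shows that exchanging one aromatic group for another at this carbon can also pass without a difference beyond the scatter. Taking the group away is therefore expected to hand back part of the gain, a modest rise in the number, a 1.9-fold higher number from compound 3 to compound 4 (0.27 log units; within the scatter). Compound 4 is estimated at 3000 nM, with a range from 1200 nM to 7500 nM.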

Compound 4, half-maximal inhibitory concentration: 1700 nM
Estimate against measurement, compound 4: 1.8-fold (0.25 log units) above, within the range that was stated.
By their numbers in this assay, from the lowest: compounds 3 and 4 (each within the scatter of the next); then compounds 2 and 1 (each within the scatter of the next).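

In this assay the change gives a 1.1-fold higher number from compound 3 to compound 4 (0.03 log units; within the scatter), so the 4-(dimethylamino)phenyl group is not alone in reaching this level at the saturated ring carbon, even though 3-hydroxyphenyl brings a hydrogen-bond donor that the leaving group lacks. The new group also stands apart from the two weaker compounds, with a 2.1-fold lower number from compound 2 to compound 4 (0.33 log units; beyond the scatter) and a 2.6-fold lower number from compound 1 to compound 4 (0.41 log units; beyond the scatter), so two differently substituted phenyl groups now share the low end of the series. Nothing measured here explains why these groups give such similar numbers.

The compounds shown leave open whether either substituent matters at all, since a plain phenyl group on the same core would test that directly. A methoxy group in place of the hydroxyl would likewise show whether the hydroxyl hydrogen counts at this position.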